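The compounds below may be only part of what the source reports. "The series", "measured", "known", "first", "only" and "open" are said of these compounds alone.

Measured so far:
- Compound 1 `C=C1CCC(c2csc(/C=C(\C)C(N)=O)c2)CC1` — in an ADME assay on NIH3T3 cells (Mus musculus) for cytotoxicity, read by CCK-8 assay, with a stated time of 24 h (a lower number here means a stronger inhibitor, a higher number a weaker inhibitor), compound 1 gives > 50000 nM, which is a limit of the assay rather than a number.
- Compound 2 `C/C(=C\c1cc(C2=CCCC2)co1)C(N)=O` — in this assay compound 2 gives 49300 nM.
- Compound 3 `C/C(=C\c1nc(-c2ccccc2)cs1)C(N)=O` — in this assay compound 3 gives > 50000 nM, again a limit rather than a number.

Compound 3 therefore stands not at a measured number but at the limit of > 50000 nM in this assay, at which 2 of the 3 values shown sit. Nothing among these three compounds gives a step between two measured values, so no measured change can be followed here; compound 2 simply gives a number, while compound 1 and compound 3 each stop at the limit.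

Compound 4 `C/C(=C\c1nc(-c2ccc(C)cc2)cs1)C(N)=O` is the next compound to be tested. It differs from compound 3 by methyl in place of hydrogen on an aromatic carbon. A change this small, with a starting point already at the limit, is expected to bring no step beyond the usual scatter: the expected step is a step that the limit leaves unreadable from compound 3 to compound 4. The estimate for compound 4 in this assay is 70000 nM, with a range from 30000 nM to 200000 nM, and most likely the assay will again report only a limit.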

Compound 4, half-maximal inhibitory concentration: > 50000 nM
Compound 4: only a limit was reported (the forecaster's own chance of this, stated with the estimate: 80%); the middle value does not contradict the limit.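

Among these compounds, compound 3 and compound 4 both stop at a limit rather than a number in this assay, so no step between them can be read: the limit of > 50000 nM in this assay, at which 3 of the 4 values shown sit. The compounds shown leave open whether methyl in place of hydrogen on an aromatic carbon changes this value at all.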